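Replacing the hydroxy on the pyrimidine of compound 2

The source may report more compounds than this note shows. Statements on the series, on what has been measured and on what is new or still open speak of the compounds shown alone.

For the measured compounds named here, compound 2 `O=C(Nc1ccc(Oc2cc(O)ncn2)cc1)Nc1cccc(C(F)(F)F)c1` gives 3200 nM in an assay on isolated protein for inhibition of serine/threonine-protein kinase TNNI3K (Homo sapiens) (on this read-out higher numbers stand for weaker inhibition and lower numbers for stronger inhibition), the highest number among the three compounds measured so far. Compound 1 `CCNc1cc(Oc2ccc(NC(=O)Nc3cccc(C(F)(F)F)c3)cc2)ncn1` gives 25 nM, and compound 3 `CNc1nccc(Oc2ccc(NC(=O)Nc3cccc(C(F)(F)F)c3)cc2)n1` gives 50 nM; the step of a 2.0-fold higher number from compound 1 to compound 3 (0.30 log units; within the scatter) lies within the scatter, so these two are not separated. Against them compound 2 stands well apart: the step of a 130-fold higher number from compound 1 to compound 2 (2.11 log units; beyond the scatter) and the step of a 64-fold lower number from compound 2 to compound 3 (1.81 log units; beyond the scatter) are both beyond the scatter, and both amount to exchanging the hydroxy for an alkylamino group on the same core.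

Compound 4 `CC(C)CNc1cc(Oc2ccc(NC(=O)Nc3cccc(C(F)(F)F)c3)cc2)ncn1` is the next member; it differs from compound 2 by isobutylamino in place of hydroxy on an aromatic carbon. The two measured steps bearing on it are exactly those above: removing the hydroxy in favour of an alkylamino group lowered the number strongly in each case, whether the amine carried an ethyl or a methyl group. Isobutylamino is a larger chain than either, and no measured compound shows what a chain of this size does, so the width of the expectation is generous. Still, the number for compound 4 is expected to fall far, roughly as a 91-fold lower number from compound 2 to compound 4 (1.96 log units; beyond the scatter). The estimate for compound 4 is 35 nM, with a range from 8 nM to 200 nM.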

Compound 4, half-maximal inhibitory concentration: 50 nM
The estimate for compound 4 lay 1.4-fold (0.15 log units) below the measured number, and the stated range covers the measured number.
By their numbers in this assay, from the lowest: compounds 1, 3 and 4 (each within the scatter of the next); then compound 2.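

Compound 4 extends the finding to a larger chain: in this assay, isobutylamino in place of hydroxy on the aromatic carbon next to the ring nitrogen gives a 64-fold lower number from compound 2 to compound 4 (1.81 log units; beyond the scatter) and places compound 4 with compound 1 and compound 3, and none of the compounds shown goes against this separation from the hydroxy compound. Within the alkylamino groups on this same core, the exchange of ethylamino for isobutylamino gives a 2.0-fold higher number from compound 1 to compound 4 (0.30 log units; within the scatter) and so does not separate the two, which means that this increase in chain size has no readable effect in this assay. No measurement at hand accounts for the gap between hydroxy and the alkylamino groups.

The compounds shown do not tell whether the low numbers depend on the amine nitrogen or on the carbon chain, a question that a methoxy group or an unsubstituted amino group at this carbon would address. Going by these compounds, how far this position accepts further change also remains open, for example with a longer chain, a morpholine ring or a chain ending in a carboxylic acid.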